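Compound 4 against compound 2: working notes

This account rests on a few compounds, and the source may have more. Where it says the series, first, only, none or still open, it means among the compounds named here.

Values in a functional assay on HeLa cells (Homo sapiens) for inhibition, read by MTT assay, with a stated time of 48 h; a higher number here means a weaker inhibitor, a lower number a stronger inhibitor:
- compound 1 `CCOC(=O)C1=C(N/N=C(\c2ccc([N+](=O)[O-])cc2)N2CCN(c3ccc(F)cc3)CC2)Nc2[nH]nc(C)c2C1c1ccc(N(C)C)cc1`: 87000 nM
- compound 2 `CCOC(=O)C1=C(N/C=N/c2nnc(S(N)(=O)=O)s2)Nc2[nH]nc(C)c2C1c1ccc(N(C)C)cc1`: 26300 nM
- compound 3 `CCOC(=O)C1=C(N/C=N/c2ncc(-c3ccccc3)s2)Nc2[nH]nc(C)c2C1c1ccc(N(C)C)cc1`: 15400 nM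

Compound 2 lies within the scatter of compound 3, while the number for compound 1 stands higher, beyond the scatter of compound 2. Compound 4 `CCOC(=O)C1=C(N/N=C(/Cl)c2ccc([N+](=O)[O-])cc2)Nc2[nH]nc(C)c2C1c1ccc(N(C)C)cc1` is unmeasured, and its difference from compound 2 is a group of 12 heavy atoms (7 carbon, 2 nitrogen, 2 oxygen, 1 chlorine; one six-membered aromatic ring of carbon only) in place of a group of 11 heavy atoms (3 carbon, 4 nitrogen, 2 oxygen, 2 sulfur; one five-membered aromatic ring with 3 hetero atoms), on an amine nitrogen. Among the measured compounds shown here, the one measured step bearing on this is a 1.7-fold lower number from compound 2 to compound 3 (0.23 log units; within the scatter), which stayed within the scatter. Compound 1, at 87000 nM, also carries a six-membered aromatic ring of carbon only, so a slight rise is expected in this assay, though none beyond the scatter. The expected step is a 1.3-fold higher number from compound 2 to compound 4 (0.12 log units; within the scatter). For compound 4 the estimated value is 35000 nM, with an expected range of 12000 nM to 100000 nM.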

Compound 4, half-maximal inhibitory concentration: 46200 nM
For compound 4 the middle estimate is 1.3-fold (0.12 log units) below the measured one; low and high end bracket the measured number.
By their numbers in this assay, from the lowest: compounds 3, 2, 4 and 1 (each within the scatter of the next, the first and the last beyond it).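

In this assay, exchanging the group on the amine nitrogen gives a 1.8-fold higher number from compound 2 to compound 4 (0.24 log units; within the scatter). The earlier step, a 1.7-fold lower number from compound 2 to compound 3 (0.23 log units; within the scatter), only replaced one group built on a five-membered aromatic ring with another. This exchange goes further, bringing in a six-membered aromatic ring of carbon only together with chlorine, and the number still stays within the scatter of compound 2.

From the compounds shown here alone, whether a carboxylic acid or a simple amine at this place would give a step beyond the scatter remains open. No measurement at hand accounts for the result.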